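The compounds below may be only part of what the source reports. "The series", "measured", "known", "first", "only" and "open" are said of these compounds alone.

Working notes on the series. Going by the values given here, in a functional assay on MIA PaCa-2 cells (Homo sapiens) for inhibition, read by MTT assay, with a stated time of 72 h (a lower number here means a stronger inhibitor, a higher number a weaker inhibitor), compound 2 `CCCCCCCC/C=C\CCCCCCCCOC[C@@H]1CCCN1` gives 5400 nM, the only actual number so far. Compound 1 `CCCCCCCC/C=C/CCCCCCCCOC[C@@H]1CCCN1C(=O)OC(C)(C)C` gives > 100000 nM, which is a limit of the assay and not a number. Among the compounds with values here, with only one number and one limit, the series offers no measured step to calibrate the next change.

Compound 3 `CCCCCCCC/C=C/CCCCCCCCOC[C@@H]1CCCN1` is the next to be read in this assay. Against compound 2 the change is the two compounds have the same atoms and bonds and differ only in configuration as drawn: 1 of 2 stereo elements differ; a double bond is drawn Z in compound 2 and E in compound 3: a double bond is drawn Z in compound 2 and E in compound 3, and the two compounds have the same atoms and bonds. No direction can be argued from the data, so the expectation stays anchored on compound 2 at 5400 nM, with no shift beyond the scatter. The estimated change is small, a 1.1-fold higher number from compound 2 to compound 3 (0.05 log units; within the scatter). For compound 3 the expected value is 6000 nM, with an estimated range of 2500 nM to 15000 nM.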

Compound 3, half-maximal inhibitory concentration: 4200 nM
For compound 3 the middle estimate is 1.4-fold (0.15 log units) above the measured one; low and high end bracket the measured number.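

In this assay, going by these compounds alone, the geometry of the double bond appears as a 1.3-fold lower number from compound 2 to compound 3 (0.11 log units; within the scatter) and so does not separate the Z and E forms of the free amine; this is the first measured step at that double bond. At the ring nitrogen, hydrogen in place of tert-butoxycarbonyl on an amine nitrogen in a ring gives an at least 23-fold lower number from compound 1 to compound 3 (1.37 log units; beyond the scatter) and is the only large step shown. Compound 1 stands at a limit of the assay and not a number, so the full size of that step stays unfixed: the limit of > 100000 nM in this assay, at which 1 of the 3 values shown sits.

Open is how a methyl group or an acetyl amide on that ring nitrogen would read against the free amine, given that only hydrogen and tert-butoxycarbonyl are shown there. Equally open, going by these compounds, is how a shorter chain, or a saturated chain in place of the one with the double bond, would read in this assay against compound 3.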